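Adding a Methoxy Group to a Modest Hit

The source may hold more compounds than are shown below. What is called first, only, known or untested is meant among the compounds shown, and "the series" means these compounds.

Three compounds were examined in a functional assay, read by spectrophotometry, with a stated time of 30 min, tested at 100 uM; on this read-out lower numbers stand for a weaker effect and higher numbers for a stronger effect at the one concentration tested. Compound 1, `O=C(O)Cn1c(=O)c(-c2ccccc2)nc2cccnc21`, was included in the set but gave "not determined" (no result reported) in this assay. Compound 2, `O=C(O)Cn1c(=O)c(/C=C/c2ccc(O)c(O)c2)nc2cc(Br)cnc21`, gave 95.8%. Compound 3, `COc1ccc(-c2nc3cccnc3n(CC(=O)O)c2=O)cc1O`, gave 32.1%, the lowest of the two numbers available; compound 2 stands well above it, by a gap beyond the usual scatter.

Compound 4, `COc1cc(-c2nc3cccnc3n(CC(=O)O)c2=O)cc(O)c1OC`, has not yet been measured. It differs from compound 3 by one change: methoxy in place of hydrogen on an aromatic carbon. Among the compounds with values here, no pair of measured compounds shows what this particular change does, so the direction of the step is open. The added methoxy group sits on the same aromatic ring that already carries a methoxy group and a hydroxy group, and it is a small change to a compound that is already only modestly active.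

Compound 4 is therefore expected to stay close to compound 3, with an estimated step of a number 2.9 percentage points higher from compound 3 to compound 4 (within the scatter) that may fall within the scatter in either direction. The estimate for compound 4 in this assay is 35%, with a range from 12% to 62%.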

Compound 4, a percentage reported as activity, at one concentration (the size of the read-out at that concentration, not a potency): 20.5%
For compound 4 the middle estimate is 14.5 percentage points above the measured one, within the range that was stated.
By their numbers in this assay, from the lowest: compound 4; then compound 3; then compound 2.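

Placing a methoxy group on this aromatic carbon, ortho to a methoxy group and meta to a hydroxy group, produces a measurable change in this assay: a number 11.6 percentage points lower from compound 3 to compound 4 (beyond the scatter). Within the data shown here, this is the first measured pair to isolate this change, and it shows that on this core the extra methoxy group lowers the read-out rather than raising it, although the step is modest. The data offer no measurement that accounts for the drop.

From the compounds shown here alone, it remains open whether an amine, a fluorine atom or a longer chain such as ethoxy on the same aromatic carbon would lower the number as well. Also open, going by these compounds, is whether adding a methoxy group would have a similar effect on a compound with a much higher read-out, such as compound 2 at 95.8%.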